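Moving one methyl group on compound 3

This account rests on a few compounds, and the source may have more. Where it says the series, first, only, none or still open, it means among the compounds named here.

Within the data shown here, in a functional assay on MCF7 cells (Homo sapiens) for cytotoxicity, read by ELISA, with a stated time of 4 days (a higher number here means a weaker inhibitor, a lower number a stronger inhibitor), compound 3 `Cc1ccccc1-c1cc(-c2ccoc2)cc(-c2ccc(Cl)s2)n1` gives 1430 nM as the lowest of three numbers so far. Compound 1 `Cc1ccsc1-c1cc(-c2ccco2)cc(-c2ccccc2Cl)n1` at 14200 nM and compound 2 `Cc1ccsc1-c1cc(-c2ccoc2)cc(-c2ccc(Cl)cc2)n1` at 20300 nM both sit higher, beyond the scatter.

Compound 4 `Cc1ccc(-c2cc(-c3ccoc3)cc(-c3ccc(Cl)s3)n2)cc1` has the same atoms as compound 3 joined differently, with 4-methylphenyl in place of 2-methylphenyl on an aromatic carbon next to the ring nitrogen 4-methylphenyl in place of 2-methylphenyl on an aromatic carbon and nothing else changed.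

Among the measured compounds shown here, no two measured compounds differ in one place only, so no direct guide exists for this change. Compound 3 at 1430 nM already sits lowest, so a move up seems likelier than a move down. A modest estimated step of a 2.1-fold higher number from compound 3 to compound 4 (0.32 log units; beyond the scatter) is expected in this assay toward a higher number. Compound 4 is estimated at 3000 nM with an expected range from 800 nM to 10000 nM in this estimate.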

Compound 4, half-maximal inhibitory concentration: 5340 nM
The estimate for compound 4 lay 1.8-fold (0.25 log units) below the measured number, and the stated range covers the measured number.
By their numbers in this assay, from the lowest: compound 3; then compound 4; then compounds 1 and 2 (each within the scatter of the next).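

In this assay, putting 4-methylphenyl in place of 2-methylphenyl gives a 3.7-fold higher number from compound 3 to compound 4 (0.57 log units; beyond the scatter). Among these compounds, this is the first comparison here in which only one place differs, and it shows that the number responds to where the methyl group sits on this phenyl ring, even with the same atoms. Nothing available gives a reason for this step. As far as these compounds go, whether an amine or a carboxylic acid in place of the methyl group would lower the number stays open, as does whether this shift acts alike with other groups on the shared core.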